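The compounds below may be only part of what the source reports. "The series", "measured", "known", "first", "only" and "open" are said of these compounds alone.

Working notes on the series. In a functional assay on PC-3 cells (Homo sapiens) for inhibition, read by sulforhodamine B assay, with a stated time of 48 h (a higher number here means a weaker inhibitor of growth, a lower number a stronger inhibitor of growth), compound 1 `COC1=CC(=O)C(C/C=C(\C)CC/C=C(\C)CCC=C(C)C)=C(C)C1=O` returns only a limit of the assay, > 30000 nM. Compound 2 `COC1=C(OC)[C@H](OC(C)=O)[C@H](C/C=C(\C)CC/C=C(\C)C[C@H](O)C=C(C)C)[C@@H](C)C1=O` also returns only a limit in this assay, > 30000 nM. Compound 3 `COC1=C(OC)[C@H](O)[C@H](C/C=C(\C)CC/C=C(\C)C[C@H](O)C=C(C)C)[C@@H](C)C1=O`, too, gives a limit in this assay, > 30000 nM. Going by the values given here, the single measured step, a step that the two limits leave unreadable from compound 2 to compound 3, therefore cannot be read. Compound 4 `COC1=C(OC)[C@H](OC(C)=O)[C@H](C/C=C(\C)CC/C=C(\C)C[C@H](O)C[C@@H](C)C(O)O)[C@@H](C)C1=O` differs from compound 2 by a group of 6 heavy atoms (4 carbon, 2 oxygen; no ring) in place of a group of 4 heavy atoms (4 carbon; no ring), on a saturated chain carbon bound to an oxygen on a saturated carbon and a saturated chain carbon. Among the compounds with values here, no measured step covers this change, and the sole evidence is the limit of > 30000 nM in this assay, at which 3 of the 3 values shown sit, so no shift beyond the scatter can be foreseen in this assay. Compound 4 is expected to give 40000 nM, with a range of 15000 nM to 150000 nM. That estimate implies a step that the limit leaves unreadable from compound 2 to compound 4, and most likely another limit rather than a number.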

Compound 4, concentration for 50% growth inhibition: > 30000 nM
Compound 4 gave a limit, no number; the forecaster's own chance of this, stated with the estimate: 80%; the middle value does not contradict the limit.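

Compound 4, like compound 2, gives only a limit, and no new step can be read between them. As far as these compounds go, whether any change to these structures yields a number rather than a limit in this assay remains open.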